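Anilino-thiazolyl enones: exchanging the arylamine substituent

The compounds below may be only part of what the source reports. "The series", "measured", "known", "first", "only" and "open" are said of these compounds alone.

Among the compounds with values here, in a functional assay on BGC-823 cells (Homo sapiens) for cytotoxicity, read by MTT assay (a higher number here means a weaker inhibitor, a lower number a stronger inhibitor), compound 2 `Cc1nc(Nc2ccc(Cl)c(Cl)c2)sc1C(=O)/C=C/c1ccccc1` gives 10600 nM, the only number in the set. Compound 1 `COc1cccc(/C=C/C(=O)c2sc(Nc3cccc(C)c3)nc2C)c1` gives > 25000 nM, which is a limit of this assay and not a number. Compound 3 `Cc1cccc(Nc2nc(C)c(C(=O)/C=C/c3ccccc3)s2)c1` has not yet been measured in this assay. It differs from compound 2 in one place: 3-methylphenyl in place of 3,4-dichlorophenyl on a nitrogen on an aromatic ring. Within the data shown here, no measured pair in the set tracks this exact exchange, so the size of the step must be judged from the surroundings. Compound 1 also bears 3-methylphenyl on a nitrogen on an aromatic ring and reaches only the limit (the limit of > 25000 nM in this assay, at which 1 of the 2 values shown sits). On that basis compound 3 is expected to lose potency, with a step of a 1.9-fold higher number from compound 2 to compound 3 (0.28 log units; within the scatter) that goes beyond the scatter toward weaker inhibition. Compound 3 is thus estimated at 20000 nM, within 7000 nM to 60000 nM, with a real chance that only a limit is reported.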

Compound 3, half-maximal inhibitory concentration: 13600 nM
Beside the measured number, compound 3's estimate is 1.5-fold (0.17 log units) above it; measured number inside the range.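

In this assay, 3-methylphenyl in place of 3,4-dichlorophenyl on a nitrogen on an aromatic ring gives a 1.3-fold higher number from compound 2 to compound 3 (0.11 log units; within the scatter), so the two aryl groups cannot be told apart at this position. Hydrogen in place of methoxy on an aromatic carbon gives an at least 1.8-fold lower number from compound 1 to compound 3 (0.26 log units; that floor lies within the scatter), which shows that 3-methylphenyl on this nitrogen does not by itself hold a compound at the limit, although the pair gives only a floor for the size of that exchange. Compound 1 carries a limit of the assay and not a number: the limit of > 25000 nM in this assay, at which 1 of the 3 values shown sits.

Still open, from the compounds shown here alone, is whether a more different group on this nitrogen, such as a pyridyl ring or a phenyl bearing a carboxylic acid, would move the number beyond the scatter. Whether methoxy in compound 1 can be read as a true loss also remains unsettled.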